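A few compounds are considered here, and "the series" means these few. Any claim that something is new, unique, unknown or untested is made for them only; others in the source may bear on it.

Compound 1 `COc1ccc(/C=C2\CCC/C(=C\c3cccc(OC)c3OC)C2=O)cc1` carries two aryl groups on the shared core; in a functional assay on HT-1080 cells (Homo sapiens) for cytotoxicity, read by MTT assay, with a stated time of 72 h (a lower number here means a stronger inhibitor, a higher number a weaker inhibitor), compound 1 gives 16300 nM. Compound 2 `COc1cccc(/C=C2\CCC/C(=C\c3cccc(O)c3)C2=O)c1OC` gives 8500 nM in this assay. The change between them, (3-hydroxyphenyl in place of 4-methoxyphenyl on a double-bonded chain carbon bound to a double-bonded ring carbon), made a 1.9-fold lower number from compound 1 to compound 2 (0.28 log units; within the scatter). Compound 3 `COc1ccc(/C=C2\CCC/C(=C\c3ccc(OC)c(OC)c3)C2=O)cc1` has the same atoms as compound 1 joined differently; the difference between the two cores is not broken down here. In this assay compound 3 gives 7200 nM, a number lower than that of compound 1 and beyond the scatter, while the gap to compound 2 lies within the scatter, so no order between compound 2 and compound 3 is claimed. Compound 4 `COc1ccc(/C=C2\CCC/C(=C\c3cccc(O)c3)C2=O)cc1OC` has not yet been measured. It differs from compound 3 by 3-hydroxyphenyl in place of 4-methoxyphenyl on a double-bonded chain carbon bound to a double-bonded ring carbon, the same change that leads from compound 1 to compound 2, occurring twice among these four compounds. Because that change made a 1.9-fold lower number from compound 1 to compound 2 (0.28 log units; within the scatter), a step of similar size is expected from compound 3 to compound 4, a 1.6-fold lower number from compound 3 to compound 4 (0.20 log units; within the scatter), resting on a single earlier instance. Compound 4 is therefore estimated at 4500 nM, between 2000 nM and 10000 nM in this assay.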

Compound 4, half-maximal inhibitory concentration: 1700 nM
For compound 4 the middle estimate is 2.6-fold (0.42 log units) above the measured one, and the stated range ends above it.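

In this assay, 3-hydroxyphenyl in place of 4-methoxyphenyl on a double-bonded chain carbon bound to a double-bonded ring carbon gave a 4.2-fold lower number from compound 3 to compound 4 (0.63 log units; beyond the scatter). Set beside the earlier instance of the same change, the step shows no difference that can be told apart between the two cores: the same change on two cores in this assay, a 1.9-fold lower number (0.28 log units; within the scatter) from compound 1 to compound 2 and a 4.2-fold lower number (0.63 log units; beyond the scatter) from compound 3 to compound 4, 2.2-fold (0.34 log units) apart, within the scatter of two such steps. This supports carrying the change between these two cores only; it does not show that the change transfers to other cores, and with only the newer step beyond the scatter, two instances fix neither a reliable size for the step nor a reason for it.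

As far as these compounds go, it remains open whether the hydroxyl itself matters or whether a plain phenyl would give a similar step in this assay. Also open, from the compounds shown here alone, is how an amine or a carboxylic acid in place of that hydroxyl would behave on either core.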